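Swapping bromine for chlorine on a cytotoxicity-silent scaffold

The source may report more compounds than this note shows. Statements on the series, on what has been measured and on what is new or still open speak of the compounds shown alone.

Compound 2 `CCNc1ncnc2c1c(Br)cn2COC(CO)CO` carries an ethylamino group and a bromo substituent on the shared core. In an ADME assay on HFF cells (Homo sapiens) for cytotoxicity (on this read-out lower numbers stand for stronger inhibition and higher numbers for weaker inhibition), compound 2 gives only a limit, > 100000 nM, and no number. Compound 1 `Nc1ncnc2c1ccn2COC(CO)CO` likewise reaches only the limit, > 100000 nM, in this assay. Compound 3 `OCC(CO)OCn1ccc2cncnc21` also stops at the limit, > 100000 nM. Within the data shown here, the single step between measured compounds, a step that the two limits leave unreadable from compound 1 to compound 3, cannot be read, and the limit of > 100000 nM in this assay, at which 3 of the 3 values shown sit, is the only evidence the series offers: every value shown is a limit.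

Compound 4 `CCNc1ncnc2c1c(Cl)cn2COC(CO)CO` differs from compound 2 by chloro in place of bromo on an aromatic carbon. Among the measured compounds shown here, no measured step in this assay addresses a halogen exchange, and no step at all has a readable size, so there is nothing to suggest the chloro analogue departs from the behaviour of compound 2. The step from compound 2 to compound 4 is therefore expected to be a step that the limit leaves unreadable from compound 2 to compound 4, that is, none beyond the scatter, with compound 4 most likely remaining at the limit.

Compound 4 is estimated at 200000 nM in this assay, within a range of 70000 nM to 600000 nM.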

Compound 4, half-maximal inhibitory concentration: > 100000 nM
Compound 4: no number, only a limit; the forecaster's own chance of this, stated with the estimate: 90%; the middle value is on the limit's open side.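

Compound 4, like compound 2, gives only a limit in this assay, so no step can be read for chloro in place of bromo on an aromatic carbon: the limit of > 100000 nM in this assay, at which 4 of the 4 values shown sit. The compounds shown leave open whether any of them would give an actual half-maximal value in this assay, and whether the two halogens differ there at all.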